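The compounds below may be only part of what the source reports. "The series", "measured", "known", "first", "only" and "open" are said of these compounds alone.

In a functional assay on HCC827 cells (Homo sapiens) for antiproliferative activity, read by MTT assay, with a stated time of 72 h (a higher number here means a weaker inhibitor, a lower number a stronger inhibitor), compound 2 `CN1CCN(c2ccc(Nc3ncc4nc(Nc5ccc(F)cc5)n(CCNS(=O)(=O)C5CC5)c4n3)cc2)CC1` gives 50 nM, the second highest of the three numbers measured. Compound 1 `CN1CCN(c2ccc(Nc3ncc4nc(Nc5ccccc5)n([C@H]5CCN(S(C)(=O)=O)C5)c4n3)cc2)CC1` gives 17 nM, and compound 3 `CN1CCN(c2ccc(Nc3ncc4nc(Nc5ccccc5)n([C@H]5CCNC5)c4n3)cc2)CC1` gives 530 nM. Compound 4 `CN1CCN(c2ccc(Nc3ncc4nc(Nc5ccc(F)cc5)n([C@@H]5CCCN(C(=O)CO)C5)c4n3)cc2)CC1` differs from compound 2 by 1-((hydroxymethyl)carbonyl)piperidin-3-yl in place of 2-((cyclopropylsulfonyl)amino)ethyl on an aromatic nitrogen. Going by the values given here, one measured step bears on this change: a 31-fold higher number from compound 1 to compound 3 (1.49 log units; beyond the scatter), where hydrogen replaced methylsulfonyl on an amine nitrogen in a ring. In compound 4 the ring nitrogen carries a (hydroxymethyl)carbonyl group rather than hydrogen, so the pattern of compound 1, which gives 17 nM, is the closer comparison. The step from compound 2 to compound 4 is therefore expected to be a 1.8-fold lower number from compound 2 to compound 4 (0.25 log units; within the scatter), a modest move toward a stronger inhibitor. Compound 4 is estimated at 28 nM, within 10 nM to 80 nM.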

Compound 4, half-maximal inhibitory concentration: 66 nM
For compound 4 the middle estimate is 2.4-fold (0.37 log units) below the measured one; the measured number falls inside the stated range.
By their numbers in this assay, from the lowest: compound 1; then compounds 2 and 4 (each within the scatter of the next); then compound 3.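

The step from this assay is a 1.3-fold higher number from compound 2 to compound 4 (0.12 log units; within the scatter), so in this pair the 2-((cyclopropylsulfonyl)amino)ethyl group and the 1-((hydroxymethyl)carbonyl)piperidin-3-yl group cannot be told apart on this aromatic nitrogen. A sulfonyl group is therefore not required here, since compound 4 has none and still sits level with compound 2. No measurement shown explains this result. Still open, from the compounds shown here alone, is how an amine, a carboxylic acid or a longer chain on the piperidine nitrogen would fare. The mirror-image form of compound 4 also remains unknown among the compounds shown.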